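This account rests on a few compounds, and the source may have more. Where it says the series, first, only, none or still open, it means among the compounds named here.

Working notes on the series. Three compounds carry numbers in an assay on CHO cells for antagonist activity at transient receptor potential cation channel subfamily V member 1 (Homo sapiens), read by FLIPR; on this read-out lower numbers stand for stronger inhibition and higher numbers for weaker inhibition. Compound 1 `CC1CCN(c2cc(C(F)(F)F)ccc2CNC(=O)C(C)c2ccc(NS(C)(=O)=O)c(F)c2)CC1` gives 0.9 nM; compound 2 `CCC1CCN(c2cc(C(F)(F)F)ccc2CNC(=O)C(C)c2ccc(NS(C)(=O)=O)c(F)c2)CC1` gives 0.7 nM; compound 3 `CC(C(=O)NCc1ccc(C(F)(F)F)cc1N1CCC(C)(C)CC1)c1ccc(NS(C)(=O)=O)c(F)c1` gives 1.3 nM. Compound 3 has the highest number of the three, but the step of a 1.4-fold higher number from compound 1 to compound 3 (0.16 log units; within the scatter) and the step of a 1.9-fold higher number from compound 2 to compound 3 (0.27 log units; within the scatter) both lie within the scatter, as does a 1.3-fold lower number from compound 1 to compound 2 (0.11 log units; within the scatter), so the three measured compounds are not separated from one another on this read-out.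

Compound 4 `CC(C)CCOc1cc(C(F)(F)F)ccc1CNC(=O)C(C)c1ccc(NS(C)(=O)=O)c(F)c1` is not yet measured. Its change from compound 3 is isopentyloxy in place of 4,4-dimethylpiperidin-1-yl on an aromatic carbon. Within the data shown here, none of the measured steps bears on this directly: all three compare one piperidine substituent with another, and each of them stays within the scatter. Among the measured compounds shown here, no measured compound lacks the ring at this position, and no measured compound carries an alkoxy group there, so the size of the step cannot be read from the data. The removal of the ring and its nitrogen is a larger structural change than any step measured so far, and a weaker inhibition, that is a higher number, is expected as the more likely outcome, with a wide range. Compound 4 is estimated at 5 nM, between 1 nM and 30 nM, meaning an expected step of a 3.8-fold higher number from compound 3 to compound 4 (0.59 log units; beyond the scatter).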

Compound 4, inhibition constant: 0.5 nM
Beside the measured number, compound 4's estimate is 10-fold (1.00 log units) above it, outside the stated range (below it).
By their numbers in this assay, from the lowest: compounds 4, 2, 1 and 3 (each within the scatter of the next, the first and the last beyond it).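

Among these compounds, the aromatic carbon carrying these groups does not depend on a piperidine in this assay: isopentyloxy in place of 4,4-dimethylpiperidin-1-yl gives a 2.6-fold lower number from compound 3 to compound 4 (0.41 log units; beyond the scatter), the only step beyond the scatter, while the same group set against the other two piperidines gives a 1.4-fold lower number from compound 2 to compound 4 (0.15 log units; within the scatter) and a 1.8-fold lower number from compound 1 to compound 4 (0.26 log units; within the scatter), both within the scatter. Across these four compounds, then, neither the six-membered non-aromatic ring nor its nitrogen is needed for a number in this range, since an open chain joined through oxygen serves equally well against 4-methylpiperidin-1-yl and 4-ethylpiperidin-1-yl. Nothing available explains this result.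

The compounds shown hold a single alkoxy group at this carbon, so how the number follows chain length and branching, as with a shorter ethoxy, a longer hexyloxy or an unbranched pentyloxy group, stays open. Also open, as far as these compounds go, is whether the linking oxygen matters, a question that a pentyl chain joined directly through carbon or an isopentylamino group at the same place would address.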